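From 4-chlorophenyl to phenyl at the assay limit

This account rests on a few compounds, and the source may have more. Where it says the series, first, only, none or still open, it means among the compounds named here.

Compound 1 `COc1cc(-n2ncnc2-c2ccc(Cl)cc2)cc(OC)c1OC` was tested in a functional assay on K562 cells (Homo sapiens) for antiproliferative activity, read by MTT assay, with a stated time of 72 h; a lower number here means a stronger inhibitor, a higher number a weaker inhibitor. In this assay compound 1 gives > 10000 nM, which is a limit and not a number. It therefore stands at the limit of > 10000 nM in this assay, at which 2 of the 3 values shown sit. Compound 3 `COc1cc(-c2ncnn2-c2ccccc2)cc(OC)c1OC` gives > 10000 nM, also a limit. Compound 2 `CCOc1ccc(-c2ncnn2-c2cc(OC)c(OC)c(OC)c2)cc1Cl` alone gives a measured number, 20 nM.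

The next compound, compound 4 `COc1cc(-n2ncnc2-c2ccccc2)cc(OC)c1OC`, carries hydrogen in place of chloro on an aromatic carbon, the change from 4-chlorophenyl to phenyl (hydrogen in place of chloro on an aromatic carbon). Among the measured compounds shown here, no measured pair in this small set shows this change on its own, so its size must be estimated. Compound 1, at > 10000 nM, offers no number to start from, and a large gain in potency is not expected. The estimated step that the limit leaves unreadable from compound 1 to compound 4 is expected to stay within the scatter, with no firm direction. A report of compound 4 as a limit is also expected. For compound 4 the estimated value is 12000 nM, with an expected range from 4000 nM to 30000 nM.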

Compound 4, half-maximal inhibitory concentration: > 10000 nM
Compound 4 gave a limit, no number; the forecaster's own chance of this, stated with the estimate: 85%; the middle value lies beyond the limit too.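

Among the compounds shown here, compound 1 and compound 4 both stand at a limit in this assay, so no step between them can be read: the limit of > 10000 nM in this assay, at which 3 of the 4 values shown sit. The compounds shown leave open whether hydrogen in place of chloro changes potency at all on a core that gives a measured number.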